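Cytotoxicity in MT4 cells: a naphthyl amide replaces dichlorophenyl

The compounds below may be only part of what the source reports. "The series", "measured", "known", "first", "only" and "open" are said of these compounds alone.

Compound 1 `O=C1c2ccccc2C(=O)N1CCOC(=S)N(C(=O)c1cc(F)ccc1F)c1ccc(Cl)cc1`: 54000 nM
Compound 2 `O=C1c2ccccc2C(=O)N1CCOC(=S)N(C(=O)c1ccc(Cl)cc1Cl)c1ccc(Cl)cc1`: 18000 nM

Within the data shown here, in an ADME assay on MT4 cells (Homo sapiens) for cytotoxicity, read by MTT assay (a lower number here means that less compound is tolerated, a higher number that more compound is tolerated), compound 2 stands lowest of the two numbers known, with compound 1 sitting higher by a 3.0-fold lower number from compound 1 to compound 2 (0.48 log units; beyond the scatter). Compound 3 `O=C1c2ccccc2C(=O)N1CCOC(=S)N(C(=O)c1ccc2ccccc2c1)c1ccc(Cl)cc1` differs from compound 2 by naphthalen-2-yl in place of 2,4-dichlorophenyl on a carbonyl carbon. Among the measured compounds shown here, the only measured step, from compound 1 to compound 2, changed the same carbonyl-borne aryl group and moved the number beyond the scatter, so this position is sensitive. For the measured compounds named here, with no direct precedent for naphthalen-2-yl, compound 3 is expected to stay near compound 2, perhaps modestly lower, a change of a 1.3-fold lower number from compound 2 to compound 3 (0.11 log units; within the scatter). The estimate for compound 3 is 14000 nM, ranging from 5000 nM to 40000 nM.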

Compound 3, half-maximal cytotoxic concentration: 37000 nM
The estimate for compound 3 lay 2.6-fold (0.42 log units) below the measured number, within the range that was stated.
By their numbers in this assay, from the lowest: compound 2; then compounds 3 and 1 (each within the scatter of the next).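

In this assay, naphthalen-2-yl in place of 2,4-dichlorophenyl gives a 2.1-fold higher number from compound 2 to compound 3 (0.31 log units; beyond the scatter), so the sensitivity of this carbonyl-borne position extends to a group with two aromatic rings and no chlorine. Against 2,5-difluorophenyl, the same group gives a 1.5-fold lower number from compound 1 to compound 3 (0.16 log units; within the scatter), which leaves compound 2 alone apart from the other two compounds. No measurement shown here explains this difference. From the compounds shown here alone, whether an amine or a carboxylic acid on the aryl group would stay with compound 1 and compound 3 or fall toward compound 2 remains open.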